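The source may report more compounds than this note shows. Statements on the series, on what has been measured and on what is new or still open speak of the compounds shown alone.

In a toxicity assay on HT-29 cells (Homo sapiens) for cytotoxicity (on this read-out higher numbers stand for lower toxicity in this test and lower numbers for higher toxicity in this test), compound 3 (`CN1C(=S)[C@@H](NC(=O)c2nc(Cc3ccccc3)n(C3CCC3)n2)COc2ccccc21`) gives > 100000 nM as a limit and not a number. Compound 1 (`CCn1nc(C(=O)N[C@H]2COc3ccccc3N(C)C2=S)nc1Cc1ccccc1`) gives > 100000 nM as a limit too. Compound 2 (`CN1C(=S)[C@@H](NC(=O)c2nc(Cc3ccccc3)n(CCCCC#N)n2)COc2ccccc21`) gives > 100000 nM as a limit too. All three readings therefore rest on the same mark (the limit of > 100000 nM in this assay, at which 3 of the 3 values shown sit) and compound 3 has no exact number of its own. Compound 4 (`CN1C(=S)[C@@H](NC(=O)c2nc(Cc3ccccc3)n(C3CCOCC3)n2)COc2ccccc21`) carries oxan-4-yl in place of cyclobutyl on an aromatic nitrogen. Two measured steps change the group on an aromatic nitrogen (a step that the two limits leave unreadable from compound 1 to compound 3; a step that the two limits leave unreadable from compound 2 to compound 3) and neither has a readable size. With compound 3 as the starting point and its neighbours held at the same limit (the limit of > 100000 nM in this assay, at which 3 of the 3 values shown sit) no step beyond the scatter is expected, and no direction can be argued from these data. The expected change is a number no higher from compound 3 to compound 4 (the limit leaves the size open) in this reading. Compound 4 is estimated at 100000 nM with an expected range from 50000 nM to 200000 nM and will most likely report only a limit again.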

Compound 4, half-maximal cytotoxic concentration: > 100000 nM
Compound 4: a limit, no number (the forecaster's own chance of this, stated with the estimate: 90%); the middle value sits exactly at the limit.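

Among these compounds, compound 4 joins compound 1, compound 2 and compound 3 in giving a limit and not a number, so no step among them can be read: the limit of > 100000 nM in this assay, at which 4 of the 4 values shown sit. The compounds shown leave open how the groups on the aromatic nitrogen compare in this assay at any concentration beyond that limit.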